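Fluoro substitution on the anilide ring of salicylanilides

The compounds below may be only part of what the source reports. "The series", "measured", "known", "first", "only" and "open" are said of these compounds alone.

Measured compounds:
compound 1, `O=C(Nc1cccc(C(F)(F)F)c1)c1cc(Cl)ccc1O`: 5900 nM
compound 2, `O=C(Nc1cc(C(F)(F)F)ccc1F)c1cc(Cl)ccc1O`: 2600 nM
compound 3, `O=C(Nc1ccc(F)c(F)c1)c1cc(Cl)ccc1O`: 7700 nM

All three numbers come from an ADME assay on cells (Macrophage, Mus musculus) for cytotoxicity, read by resazurin assay, with a stated time of 3 days; on this read-out lower numbers stand for stronger inhibition and higher numbers for weaker inhibition. Compound 1 and compound 2 differ by one change, (fluoro in place of hydrogen on an aromatic carbon), and the step is a 2.3-fold lower number from compound 1 to compound 2 (0.36 log units; beyond the scatter). Compound 3 gives 7700 nM against compound 1 at 5900 nM, which lies within the scatter; the difference between the cores of compound 3 and compound 1 is not broken down here.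

Compound 4, `O=C(Nc1ccc(F)c(F)c1F)c1cc(Cl)ccc1O`, is not yet measured. It arises from compound 3 by fluoro in place of hydrogen on an aromatic carbon, the same kind of change as from compound 1 to compound 2, though the surroundings differ: here the entering fluoro is ortho to a fluoro group and meta to a fluoro group, whereas before it was para to a trifluoromethyl group. Resting on the single example a 2.3-fold lower number from compound 1 to compound 2 (0.36 log units; beyond the scatter), the expected step is a 1.9-fold lower number from compound 3 to compound 4 (0.28 log units; within the scatter), perhaps somewhat smaller given the different surroundings. Compound 4 is thus estimated at 4000 nM, between 1800 nM and 9000 nM.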

Compound 4, half-maximal inhibitory concentration: 6700 nM
Compound 4: middle estimate off by 1.7-fold (0.22 log units), on the low side, within the range that was stated.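

In this assay, fluoro in place of hydrogen on an aromatic carbon gives a 1.1-fold lower number from compound 3 to compound 4 (0.06 log units; within the scatter), so on this core the change leaves no step beyond the scatter. Set beside the earlier step, the two cores cannot be told apart: the same change on two cores in this assay, a 2.3-fold lower number (0.36 log units; beyond the scatter) from compound 1 to compound 2 and a 1.1-fold lower number (0.06 log units; within the scatter) from compound 3 to compound 4, 2.0-fold (0.30 log units) apart, within the scatter of two such steps. Two steps show no measurable dependence on the core, but they do not establish that the change carries over unaltered or that it lowers the number in general.

Open, going by these compounds, is whether the step would hold on a core bearing a nitrile or a methoxy group in place of the trifluoromethyl. Also open, on these data alone, is how an amine or a carboxylic acid in place of the entering fluoro would read in this assay.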